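This account rests on a few compounds, and the source may have more. Where it says the series, first, only, none or still open, it means among the compounds named here.

Values in a physicochemical assay for pharmacokinetics, at pH 6 (on this read-out higher numbers stand for a longer-lived compound and lower numbers for a shorter-lived compound), for the compounds measured so far:
- compound 1 `O=C(Sc1cccnc1C(=O)O)c1ccccc1` gives 21.1 h
- compound 2 `O=C(Sc1cccnc1C(=O)O)c1ccc(Cl)cc1` gives 7.9 h
- compound 3 `COc1ccc(C(=O)Sc2cccnc2C(=O)O)cc1` gives 43.9 h

Compound 3 holds the highest number of the three, and compound 1 is its nearest neighbour. The next compound to be measured is compound 4 `Cc1ccc(C(=O)Sc2cccnc2C(=O)O)cc1`, which has methyl in place of methoxy on an aromatic carbon and keeps the rest of compound 3 unchanged.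

Going by the values given here, no measured step makes this exact swap, so the evidence is indirect. On the same carbon, the data show a 2.1-fold higher number from compound 1 to compound 3 (0.32 log units; beyond the scatter) with methoxy in place of hydrogen, and a 2.7-fold lower number from compound 1 to compound 2 (0.43 log units; beyond the scatter) with chloro in place of hydrogen. Methoxy in place of chloro gives a 5.6-fold higher number from compound 2 to compound 3 (0.74 log units; beyond the scatter) and is the largest step here. All three are modest but beyond the scatter.

Among the compounds with values here, with only three compounds this is a weak guide, but methyl is expected to leave compound 4 between compound 1 at 21.1 h and compound 3 at 43.9 h on this scale, closer to the upper end. The estimated step, a 1.4-fold lower number from compound 3 to compound 4 (0.14 log units; within the scatter), is expected to be slightly downward and to stay within the scatter. For compound 4 the estimate is 32 h, with an expected range from 20 h to 48 h in this assay.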

Compound 4, half-life: 25.6 h
Beside the measured number, compound 4's estimate is 1.3-fold (0.10 log units) above it; the range from low to high includes it.
By their numbers in this assay, from the lowest: compound 2; then compounds 1, 4 and 3 (each within the scatter of the next, the first and the last beyond it).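

In this assay methyl in place of methoxy, on an aromatic carbon para to a large group, gives a 1.7-fold lower number from compound 3 to compound 4 (0.23 log units; within the scatter) and so cannot be told apart from methoxy here, even though the change removes an oxygen and the hydrogen-bond acceptor that methoxy carries. Methyl in place of hydrogen gives a 1.2-fold higher number from compound 1 to compound 4 (0.08 log units; within the scatter) and is equally unresolved, so methyl lies within the scatter of both hydrogen and methoxy, although compound 1 and compound 3 differ from each other by more than the scatter. Going by these compounds alone, only methyl in place of chloro gives a step beyond the scatter, a 3.2-fold higher number from compound 2 to compound 4 (0.51 log units; beyond the scatter) and with it chloro is the one group at this position that stands clear of all three others, leaving compound 2 with the lowest number.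

These four compounds leave open how a different group on this carbon, such as an amine, a carboxylic acid or a longer chain, would behave, and whether the same order would hold elsewhere on the ring. Nothing given here explains why chloro stands apart from the other three groups.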